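Adding a second hydroxy to compound 3

The source may report more compounds than this note shows. Statements on the series, on what has been measured and on what is new or still open speak of the compounds shown alone.

Measured in a functional assay on MCF7 cells (Homo sapiens) for cytotoxicity; on this read-out higher numbers stand for weaker inhibition and lower numbers for stronger inhibition:
compound 1 `C=C/C=C\[C@H](C)[C@H](OC(N)=O)[C@@H](C)[C@H](O)[C@@H](C)C/C(C)=C\[C@H](C)[C@@H](O)[C@@H](C)/C=C\CCc1sccc1C` gives 370 nM
compound 2 `C=C/C=C\[C@H](C)[C@H](OC(N)=O)[C@@H](C)[C@H](O)[C@@H](C)C/C(C)=C\[C@H](C)[C@@H](O)[C@@H](C)/C=C\CCc1ccccc1` gives 480 nM
compound 3 `C=C/C=C\[C@H](C)[C@H](OC(N)=O)[C@@H](C)[C@H](O)[C@@H](C)C/C(C)=C\[C@H](C)[C@@H](O)[C@@H](C)/C=C\CCc1cccc(O)c1` gives 130 nM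

Compound 3 has the lowest number of the three, at 130 nM, beyond the scatter of both others. Compound 4 `C=C/C=C\[C@H](C)[C@H](OC(N)=O)[C@@H](C)[C@H](O)[C@@H](C)C/C(C)=C\[C@H](C)[C@@H](O)[C@@H](C)/C=C\CCc1cc(O)cc(O)c1` differs from it by one change, (hydroxy in place of hydrogen on an aromatic carbon), which turns 3-hydroxyphenyl into 3,5-dihydroxyphenyl. Within the data shown here, the closest precedent is the same kind of change, a 3.7-fold lower number from compound 2 to compound 3 (0.57 log units; beyond the scatter), a modest step. The step of a 2.8-fold lower number from compound 1 to compound 3 (0.45 log units; beyond the scatter) is similar in size and direction, while a 1.3-fold higher number from compound 1 to compound 2 (0.11 log units; within the scatter) shows little from the ring swap alone. Only one hydroxy addition has been measured, and a second need not repeat it. A smaller step in the same direction is therefore expected, a 1.5-fold lower number from compound 3 to compound 4 (0.18 log units; within the scatter). For compound 4 the estimated value is 85 nM, with an expected range from 28 nM to 260 nM.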

Compound 4, half-maximal inhibitory concentration: 160 nM
For compound 4 the middle estimate is 1.9-fold (0.27 log units) below the measured one; the measured number falls inside the stated range.
By their numbers in this assay, from the lowest: compounds 3 and 4 (each within the scatter of the next); then compounds 1 and 2 (each within the scatter of the next).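

In this assay a second hydroxy on the aromatic ring does not repeat the first, giving a 1.2-fold higher number from compound 3 to compound 4 (0.09 log units; within the scatter) where the first hydroxy had given a step beyond the scatter. The ring still keeps its advantage over the two other aryl ends, with a 3.0-fold lower number from compound 2 to compound 4 (0.48 log units; beyond the scatter) and a 2.3-fold lower number from compound 1 to compound 4 (0.36 log units; beyond the scatter) on the same read-out, so this ring carbon tolerates the added hydroxy. Nothing available explains this flat step.

Going by these compounds, whether a methoxy group, an amine or a carboxylic acid on that same ring carbon would match hydroxy stays open.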